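The compounds below may be only part of what the source reports. "The series", "measured", "known", "first", "only" and "open" are said of these compounds alone.

Compound 2 `COc1cccc(OC)c1OCCNCCOc1ccccc1OCc1ccccc1C` stands at the highest of the two numbers in a functional assay on PC-3 cells (Homo sapiens) for cytotoxicity, read by sulforhodamine B assay; a lower number here means a stronger inhibitor of growth, a higher number a weaker inhibitor of growth: compound 2 gives 11500 nM, while compound 1 `COc1cccc(OC)c1OCCNCCOc1ccccc1OCc1ccc(Cl)cc1` gives 2400 nM, and the step of a 4.8-fold higher number from compound 1 to compound 2 (0.68 log units; beyond the scatter) is the only measured one in the series. Compound 3 `COc1cccc(OC)c1OCCNCCOc1ccccc1OCc1ccccc1[N+](=O)[O-]` differs from compound 2 by nitro in place of methyl on an aromatic carbon. Within the data shown here, no measured step concerns this exchange; the single known step covers a different group and does not carry over, so the direction is open. A step within the scatter is therefore expected, a 1.3-fold lower number from compound 2 to compound 3 (0.11 log units; within the scatter). Compound 3 is expected at 9000 nM, within 3000 nM to 30000 nM.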

Compound 3, concentration for 50% growth inhibition: 13200 nM
Compound 3: middle estimate off by 1.5-fold (0.17 log units), on the low side; the range from low to high includes it.
By their numbers in this assay, from the lowest: compound 1; then compounds 2 and 3 (each within the scatter of the next).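

In this assay the change from 2-methylbenzyl to 2-nitrobenzyl gives a 1.1-fold higher number from compound 2 to compound 3 (0.06 log units; within the scatter) and so does not separate these two groups on this aromatic carbon. The 2-nitrophenyl exchange gives a 5.5-fold higher number from compound 1 to compound 3 (0.74 log units; beyond the scatter) and, like the 2-methylphenyl exchange, stands apart from the 4-chlorophenyl of compound 1. No available evidence bears on this result.

Compound 1 differs from compound 2 and compound 3 in both the group and its place on the ring, and these two remain unseparated. From the compounds shown here alone, how an amine or a carboxylic acid would read on this carbon remains open.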